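Ethyl to Bromo at the Same Aromatic Carbon

A few compounds are considered here, and "the series" means these few. Any claim that something is new, unique, unknown or untested is made for them only; others in the source may bear on it.

Measured so far in an assay on isolated protein for displacement of a labelled ligand from melanin-concentrating hormone receptor 1 (Homo sapiens); on this read-out higher numbers stand for weaker inhibition and lower numbers for stronger inhibition:
compound 1, `CCCc1cc(N)c2cc(NC(=O)/C=C/c3ccc(N)cc3)ccc2n1`: 190 nM
compound 2, `CCCc1cc(N)c2cc(NC(=O)/C=C/c3ccc(CC)cc3)ccc2n1`: 1.4 nM
compound 3, `CCCc1cc(NC2CC2)c2cc(NC(=O)/C=C/c3ccc(C(F)(F)F)cc3)ccc2n1`: 40 nM

Compound 2 holds the lowest number of the three in this assay, with compound 3 the nearest and compound 1 the furthest away, both gaps beyond the scatter. The unmeasured compound 4, `CCCc1cc(N)c2cc(NC(=O)/C=C/c3ccc(Br)cc3)ccc2n1`, differs from compound 2 by a single change: bromo in place of ethyl on an aromatic carbon.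

Among the compounds with values here, only one measured step touches this same aromatic carbon, a 140-fold lower number from compound 1 to compound 2 (2.13 log units; beyond the scatter), and it shows that what sits there can move the number a long way. Compound 3 differs from compound 2 in two places, so its value shows only that a trifluoromethyl on that ring, combined with a cyclopropylamino elsewhere, still yields a low number. Bromo brings neither a donor nor an acceptor, as ethyl brought none, so a rise far smaller than the step from compound 1 is expected. For compound 4 the estimate is 4 nM (range 1 nM to 20 nM), which means an expected step of a 2.9-fold higher number from compound 2 to compound 4 (0.46 log units; beyond the scatter).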

Compound 4, half-maximal inhibitory concentration: 4 nM
For compound 4 middle estimate and measured number coincide at the digits printed; measured number inside the range.
By their numbers in this assay, from the lowest: compound 2; then compound 4; then compound 3; then compound 1.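

In this assay, the change from 4-ethylphenyl to 4-bromophenyl gives a 2.9-fold higher number from compound 2 to compound 4 (0.46 log units; beyond the scatter), a modest step that is nonetheless beyond the scatter, so this aromatic carbon tolerates a single bromine atom in place of the two carbons of ethyl with only a limited loss. Bromo also stands well apart from amino at the same carbon, with a 48-fold lower number from compound 1 to compound 4 (1.68 log units; beyond the scatter), which shows that the large gap first seen with ethyl is not unique to that group. Nothing available accounts for either step.

The compounds shown leave open how chloro, methoxy or a longer chain such as propyl would read at this carbon. They also leave open what trifluoromethyl does here on its own, as compound 3 carries a cyclopropylamino as well.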